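Indole nitrogen substituent change in a metabotropic glutamate receptor 2 series

A few compounds are considered here, and "the series" means these few. Any claim that something is new, unique, unknown or untested is made for them only; others in the source may bear on it.

Measured compounds:
compound 1, `Cn1ccc2cc(-c3ccn4c(CC(F)(F)F)cnc4c3C#N)ccc21`, 230 nM
compound 3, `Cn1ccc2cc(-c3ccn4c(CC(F)(F)F)cnc4c3C#N)cc(Cl)c21`, 120 nM
compound 2, `N#Cc1c(-c2ccc3c(c2)OCCNC3)ccn2c(CC(F)(F)F)cnc12`, "not determined" (no result reported)

Three compounds sharing one core were examined in a functional assay on CHO cells for agonist activity at metabotropic glutamate receptor 2 (Homo sapiens), read by GTPgammaS binding; on this read-out higher numbers stand for an effect only at larger amounts of compound and lower numbers for an effect already at smaller amounts. Compound 1 gives 230 nM, the higher of the two numbers available, and compound 3 gives 120 nM, the step of a 1.9-fold lower number from compound 1 to compound 3 (0.28 log units; within the scatter) separating them. For the measured compounds named here, for compound 2 the result in this assay is "not determined" (no result reported), so only two numbers exist and compound 1 stands at the upper one, with compound 3 as its only neighbour.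

Compound 4, `N#Cc1c(-c2ccc3c(ccn3C3CCOCC3)c2)ccn2c(CC(F)(F)F)cnc12`, differs from compound 1 in a single place: oxan-4-yl in place of methyl on an aromatic nitrogen. Going by the values given here, the one measured step, from compound 1 to compound 3, concerns a chloro in place of hydrogen on an aromatic carbon and says nothing about the substituent on the aromatic nitrogen of the five-membered ring. Among the compounds with values here, no measured pair therefore bears directly on this change, and the expectation can rest only on the fact that the core and the remaining substituents are kept as in compound 1.

In this assay, within the data shown here, compound 4 is expected to give about 300 nM, the step of a 1.3-fold higher number from compound 1 to compound 4 (0.12 log units; within the scatter) being an estimate with a range from 90 nM to 1000 nM, since no compound measured so far tells whether oxan-4-yl in place of methyl moves the number.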

Compound 4, half-maximal effective concentration: 501 nM
Compound 4: middle estimate off by 1.7-fold (0.22 log units), on the low side, within the range that was stated.
By their numbers in this assay, from the lowest: compounds 3 and 1 (each within the scatter of the next); then compound 4.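

For the compounds shown here, the substituent on the aromatic nitrogen had not been varied among the earlier compounds, and in this assay oxan-4-yl in place of methyl gives a 2.2-fold higher number from compound 1 to compound 4 (0.34 log units; beyond the scatter) as the first measured step at this position, a modest one that lies beyond the scatter. The position therefore carries a group of six heavy atoms, with a six-membered non-aromatic ring and a hydrogen-bond acceptor, in place of a single carbon, and compound 4 still gives a number of 501 nM on this read-out, so the exchange shifts the value without removing the effect. Nothing measured in support of this series offers an explanation for the size or direction of the step.

A single pair cannot separate the contribution of the ring from that of its oxygen, and cyclohexyl, with carbon in place of that oxygen, or piperidin-4-yl, an amine, on the same aromatic nitrogen would bear on this, as would a short open chain such as ethyl. On these data alone, it also remains open whether the chloro of compound 3 and oxan-4-yl would act independently when carried together on the shared core.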